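Compound 3 to compound 4: a change on the nitrogen

The source may hold more compounds than are shown below. What is called first, only, known or untested is meant among the compounds shown, and "the series" means these compounds.

In a functional assay on K562 cells (Homo sapiens) for cytotoxicity, read by trypan blue exclusion, with a stated time of 96 h (on this read-out higher numbers stand for weaker inhibition and lower numbers for stronger inhibition), compound 1 `COc1cc(OC)c(/C=C/S(=O)(=O)Cc2ccc(OC)c(N)c2)c(OC)c1`, with hydrogen on the nitrogen, gives 2.5 nM. Compound 2 `COC(=O)C(Nc1cc(CS(=O)(=O)/C=C/c2c(OC)cc(OC)cc2OC)ccc1OC)c1ccc(Br)cc1` gives 200 nM, and compound 3 `COc1cc(OC)c(/C=C/S(=O)(=O)Cc2ccc(OC)c(N[C@@H](C)C(=O)O)c2)c(OC)c1` gives 15 nM. Compound 3 therefore holds the middle of the three numbers, set apart by a 6.0-fold higher number from compound 1 to compound 3 (0.78 log units; beyond the scatter) on one side and a 13-fold lower number from compound 2 to compound 3 (1.12 log units; beyond the scatter) on the other.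

Compound 4 `COc1cc(OC)c(/C=C/S(=O)(=O)Cc2ccc(OC)c(NC(F)(F)C(=O)O)c2)c(OC)c1` carries carboxy(difluoro)methyl in place of 1-carboxyethyl on a nitrogen on an aromatic ring. The rest of the shared core stays the same.

Among the compounds with values here, two measured steps bear on this. The nearest is a 6.0-fold higher number from compound 1 to compound 3 (0.78 log units; beyond the scatter), a modest change on introducing 1-carboxyethyl. The other, an 80-fold higher number from compound 1 to compound 2 (1.90 log units; beyond the scatter), is large, but it introduces the much different (4-bromophenyl)(methoxycarbonyl)methyl. Within the data shown here, no measured compound carries fluorine on this substituent, so the direction of the change is not settled by the data. Both the entering and leaving groups hold a carboxy group, so compound 3 at 15 nM remains the best anchor.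

Expected in this assay is a 1.5-fold higher number from compound 3 to compound 4 (0.17 log units; within the scatter), so no clear step beyond the scatter is anticipated.

The estimated value for compound 4 is 22 nM, with an expected range of 6 nM to 80 nM.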

Compound 4, half-maximal inhibitory concentration: 150 nM
The estimate for compound 4 lay 6.8-fold (0.83 log units) below the measured number; measured number above the stated range.
By their numbers in this assay, from the lowest: compound 1; then compound 3; then compounds 4 and 2 (each within the scatter of the next).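

Exchanging 1-carboxyethyl for carboxy(difluoro)methyl on this nitrogen is not a neutral swap in this assay: a 10-fold higher number from compound 3 to compound 4 (1.00 log units; beyond the scatter), so the carboxy group shared by the two substituents does not by itself fix the number at this position. All three substituents shown on the nitrogen give higher numbers than hydrogen, and this one gives a 60-fold higher number from compound 1 to compound 4 (1.78 log units; beyond the scatter), while a 1.3-fold lower number from compound 2 to compound 4 (0.12 log units; within the scatter) places the ring-free carboxy(difluoro)methyl level with the ring-bearing (4-bromophenyl)(methoxycarbonyl)methyl, so the presence of a ring does not separate the two. Nothing available explains the step from compound 3 to compound 4.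

The change replaces the methyl and the hydrogen on that carbon with two fluorines and also removes the defined stereocentre, so the step cannot yet be assigned to any one of these differences. A carboxymethyl group or a monofluorinated carboxymethyl group on the nitrogen would help divide it, and the methyl ester of carboxy(difluoro)methyl would show whether the free carboxylic acid matters for this substituent.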